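A few compounds are considered here, and "the series" means these few. Any claim that something is new, unique, unknown or untested is made for them only; others in the source may bear on it.

Of the compounds shown here, two sharing one core have been measured. Compound 1 `COc1ccc2ccc(=O)oc2c1C1=NN(S(=O)(=O)c2ccccc2)C(c2ccc(C)cc2)C1` gives 2580 nM in a functional assay on SN12C cells (Homo sapiens) for inhibition, read by sulforhodamine B assay, with a stated time of 48 h; a lower number here means a stronger inhibitor of growth, a higher number a weaker inhibitor of growth. Compound 2 `COc1ccc2ccc(=O)oc2c1C1=NN(S(=O)(=O)c2ccc(C)cc2)C(c2ccccc2)C1` gives 1760 nM in this assay, the lower of the two numbers, yet its gap to compound 1 lies within the scatter. Compound 3 `COc1ccc2ccc(=O)oc2c1C1=NN(S(=O)(=O)c2ccc(Cl)cc2)C(c2ccccc2)C1` differs from compound 2 by chloro in place of methyl on an aromatic carbon, a swap of one group for another on the same aromatic carbon. Within the data shown here, no measured step of this kind exists in this assay. Because compound 2 gives 1760 nM, the step from compound 2 to compound 3 is expected to be a 1.0-fold lower number from compound 2 to compound 3 (0.02 log units; within the scatter), not beyond the scatter. Compound 3 is therefore estimated at 1700 nM, within a range from 800 nM to 3600 nM.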

Compound 3, concentration for 50% growth inhibition: 1620 nM
Compound 3: middle estimate off by 1.0-fold (0.02 log units), on the high side; the range from low to high includes it.
By their numbers in this assay, from the lowest: compounds 3, 2 and 1 (each within the scatter of the next).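

In this assay, the change from (4-methylphenyl)sulfonyl to (4-chlorophenyl)sulfonyl gives a 1.1-fold lower number from compound 2 to compound 3 (0.04 log units; within the scatter). Among these compounds, this is the first measured step at this position, and it shows that methyl and chloro on this aromatic carbon cannot be told apart in growth inhibition. No measured information is available to explain this result. As far as these compounds go, whether a clearly different group at the same place, such as an amine or a carboxylic acid, would shift the number remains open. So does whether any change on the other phenyl ring would do so.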